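This account rests on a few compounds, and the source may have more. Where it says the series, first, only, none or still open, it means among the compounds named here.

In an ADME assay on CCRF-HSB-2 cells (Homo sapiens) for cytotoxicity, with a stated time of 7 days (a higher number here means that more compound is tolerated, a lower number that less compound is tolerated), compound 1 `CCCCCCCCSc1nc(N)nc2c1ncn2/C=C1/CC1(CO)CO` gives 60000 nM. Compound 3 `CCCCCCSc1nc(N)nc2c1ncn2/C=C1/CC1(CO)CO` gives 60000 nM, level with compound 1 at the digits shown. Compound 2 `Nc1nc(NC2CCCCC2)c2ncn(/C=C3/CC3(CO)CO)c2n1` reads > 20000 nM, which is a limit of the assay and not a number, so the steps through compound 2 cannot be sized. Compound 4 `CC(C)Sc1nc(N)nc2c1ncn2/C=C1/CC1(CO)CO` follows from compound 3 through (isopropyl in place of hexyl on a sulfur), isopropyl in place of hexyl on a sulfur. Among the measured compounds shown here, the one readable step that bears on this also alters the chain on sulfur, and it shows no change at the digits printed from compound 1 to compound 3 (within the scatter). On that single step, no shift beyond the scatter is expected in this assay. The expected outcome is no change at the digits printed from compound 3 to compound 4 (within the scatter). The estimate for compound 4 is 60000 nM, with an expected range of 25000 nM to 120000 nM.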

Compound 4, half-maximal cytotoxic concentration: 94000 nM
The estimate for compound 4 lay 1.6-fold (0.19 log units) below the measured number; the measured number falls inside the stated range.
By their numbers in this assay, from the lowest: compounds 1, 3 and 4 (each within the scatter of the next).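

In this assay, among the compounds shown here, a branched chain on the sulfur can be read for the first time, and isopropyl in place of hexyl gives a 1.6-fold higher number from compound 3 to compound 4 (0.19 log units; within the scatter). Isopropyl in place of octyl gives a 1.6-fold higher number from compound 1 to compound 4 (0.19 log units; within the scatter), so no readable step among the octyl, hexyl and isopropyl compounds leaves the scatter. The step from compound 2 cannot be read, its value being a limit: the limit of > 20000 nM in this assay, at which 1 of the 4 values shown sits.

Still open, from the compounds shown here alone, is whether a methyl on the sulfur, or a chain ending in an amine or a carboxylic acid, would move the number beyond the scatter.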